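Acrylamide to crotonamide on two cores

A few compounds are considered here, and "the series" means these few. Any claim that something is new, unique, unknown or untested is made for them only; others in the source may bear on it.

Measured so far in a functional assay on Rec1 cells (Homo sapiens) for inhibition, read by luminescence and CellTiter-Glo, with a stated time of 72 h; on this read-out higher numbers stand for weaker inhibition and lower numbers for stronger inhibition:
compound 1, `C=CC(=O)Nc1ccc(Cn2nc(-c3ccc(Oc4ccccc4)cc3)cc2C(=O)O)cc1`: > 60000 nM
compound 2, `C/C=C/C(=O)Nc1ccc(Cn2nc(-c3ccc(Oc4ccccc4)cc3)cc2C(=O)O)cc1`: 23600 nM
compound 3, `C=CC(=O)N1CCCC(n2nc(-c3ccc(Oc4ccccc4)cc3)cc2C(=O)O)C1`: 50000 nM

The value of compound 1 is a limit of this assay and not a number. In this assay compound 2 gives 23600 nM, and the step of an at least 2.5-fold lower number from compound 1 to compound 2 (0.40 log units; beyond the scatter) is itself only a bound because of the limit of > 60000 nM in this assay, at which 1 of the 3 values shown sits. The change behind it is prop-1-en-1-yl in place of vinyl on a carbonyl carbon. Compound 3 has the highest of the two plain numbers; in this assay compound 3 gives 50000 nM, a step from compound 2 that lies beyond the scatter. The difference between the core of compound 1 and the core of compound 3 is not broken down here.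

Compound 4, `C/C=C/C(=O)N1CCCC(n2nc(-c3ccc(Oc4ccccc4)cc3)cc2C(=O)O)C1`, is not yet measured. It differs from compound 3 by prop-1-en-1-yl in place of vinyl on a carbonyl carbon. Around the place the two changes are not identical: in compound 1 the carbonyl carbon's other neighbour is an amide-type nitrogen, in compound 3 an amide-type nitrogen in a ring, so this is the same kind of change, not the same change. Beside an at least 2.5-fold lower number from compound 1 to compound 2 (0.40 log units; beyond the scatter), the step expected for compound 4 is a 2.0-fold lower number from compound 3 to compound 4 (0.30 log units; within the scatter), resting on compound 3 with 50000 nM and on the earlier step. The estimate for compound 4 in this assay is 25000 nM, expected between 10000 nM and 60000 nM.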

Compound 4, half-maximal inhibitory concentration: 31000 nM
Beside the measured number, compound 4's estimate is 1.2-fold (0.09 log units) below it; the range from low to high includes it.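

In this assay, prop-1-en-1-yl in place of vinyl on a carbonyl carbon gives a 1.6-fold lower number from compound 3 to compound 4 (0.21 log units; within the scatter), so on the core of compound 3, where the carbonyl carbon's other neighbour is an amide-type nitrogen in a ring, no real effect of the change can be claimed. Two cores now carry the same kind of change, yet they do not establish that its size transfers from one to the other, nor do they establish that it fails to transfer: the same change on two cores in this assay, an at least 2.5-fold lower number (0.40 log units; beyond the scatter) from compound 1 to compound 2 and a 1.6-fold lower number (0.21 log units; within the scatter) from compound 3 to compound 4; the limit leaves it open whether they differ. Compound 1 stands at a limit and not at a number, so the earlier step is a bound and not a measured size: the limit of > 60000 nM in this assay, at which 1 of the 4 values shown sits.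

The compounds shown leave open whether a longer chain or an amine-bearing chain in place of prop-1-en-1-yl on the carbonyl carbon would give a step beyond the scatter on both cores. They also leave open how the same change would read with a methyl ester or a primary amide in place of the carboxylic acid, which all four compounds share.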